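Dimethylphenyl replaces indazolyl on the shared core

The compounds below may be only part of what the source reports. "The series", "measured", "known", "first", "only" and "open" are said of these compounds alone.

Measured compounds:
compound 1 `COc1ccc(-c2cc3nccc(-c4cc(OC)c(OC)c(OC)c4)n3n2)cc1F`: 236 nM
compound 2 `COc1cc(-c2ccnc3cc(-c4ccc5cnn(C)c5c4)nn23)cc(OC)c1OC`: 97 nM

In a functional assay on HeLa cells (Homo sapiens) for inhibition, read by CCK-8 assay, with a stated time of 48 h (on this read-out higher numbers stand for weaker inhibition and lower numbers for stronger inhibition), compound 2 stands at the lowest of the two numbers; its nearest neighbour is compound 1, which is reached by a 2.4-fold lower number from compound 1 to compound 2 (0.39 log units; beyond the scatter). Compound 3 `COc1cc(-c2ccnc3cc(-c4ccc(C)c(C)c4)nn23)cc(OC)c1OC` differs from compound 2 by 3,4-dimethylphenyl in place of 1-methyl-1H-indazol-6-yl on an aromatic carbon. Within the data shown here, the one measured step bears on this change because a 2.4-fold lower number from compound 1 to compound 2 (0.39 log units; beyond the scatter) also exchanged a substituted phenyl for the indazolyl at the same carbon of the shared core. Going back to a substituted phenyl is expected to raise the number again, by roughly a 2.5-fold higher number from compound 2 to compound 3 (0.39 log units; beyond the scatter). Compound 3 is therefore estimated at 240 nM, with a range from 90 nM to 650 nM.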

Compound 3, half-maximal inhibitory concentration: 241 nM
Compound 3: the middle estimate sits 1.0-fold (0.00 log units) below what was measured; the range from low to high includes it.
By their numbers in this assay, from the lowest: compound 2; then compounds 1 and 3 (each within the scatter of the next).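

In this assay, a 2.5-fold higher number from compound 2 to compound 3 (0.40 log units; beyond the scatter) shows that the indazolyl's edge at this carbon holds against a second substituted phenyl, not only against 3-fluoro-4-methoxyphenyl. With a 1.0-fold higher number from compound 1 to compound 3 (0.01 log units; within the scatter), 3,4-dimethylphenyl and 3-fluoro-4-methoxyphenyl do not separate, so these two sets of phenyl substituents make no readable difference here. Nothing available explains either result. The compounds shown leave open whether the indazolyl's ring nitrogens matter or only its second ring, which a naphthyl group would address. As far as these compounds go, how an amine or a carboxylic acid would read at this carbon also remains open.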